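The source may report more compounds than this note shows. Statements on the series, on what has been measured and on what is new or still open speak of the compounds shown alone.

Of the compounds shown here, two of a shared core have been measured in an assay (Cavia porcellus) for inhibition of Polyunsaturated fatty acid 5-lipoxygenase (Homo sapiens); on this read-out lower numbers stand for stronger inhibition and higher numbers for weaker inhibition. Compound 1, `NC(=O)N(O)CC1=Cc2cc(OCC3CCCCC3)ccc2OC1`, gives 1360 nM in this assay. Compound 2, `CC(C)NC(=O)N(O)CC1=Cc2cc(Oc3ccccc3)ccc2OC1`, gives 49 nM, the lower of the two numbers; compound 1 and compound 2 differ in more than one place, so the two values are simply recorded side by side, and the gap between them lies beyond the usual scatter. Compound 2 is the starting point for the step considered here.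

Compound 3, `O=C(NCc1ccccc1)N(O)CC1=Cc2cc(Oc3ccccc3)ccc2OC1`, has not yet been measured in this assay. It differs from compound 2 in one place: benzyl in place of isopropyl on an amide-type nitrogen. Among the compounds with values here, no measured pair in this set shows the effect of such a change, so the expectation rests on compound 2 alone. The hydroxyurea and the rest of the core are unchanged, and the two groups share the same counts of donors and acceptors, so the step from compound 2 to compound 3 is expected to stay within the scatter, estimated as a 1.1-fold higher number from compound 2 to compound 3 (0.05 log units; within the scatter). Compound 3 is therefore estimated at 55 nM in this assay, within a range from 15 nM to 200 nM.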

Compound 3, half-maximal inhibitory concentration: 440 nM
Estimate against measurement, compound 3: 8.0-fold (0.90 log units) below; the whole stated range lies below it.
By their numbers in this assay, from the lowest: compound 2; then compound 3; then compound 1.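

On this amide-type nitrogen, the exchange of isopropyl for benzyl in this assay gives a 9.0-fold higher number from compound 2 to compound 3 (0.95 log units; beyond the scatter), so the position responds to the identity of its substituent even though neither group carries a hydrogen-bond donor or acceptor and the hydroxyurea and the rest of the core stay the same. The earlier compounds shown here could not show this, since compound 1 and compound 2 differ in more than one place and no single change at this nitrogen had been isolated. Nothing in the available information accounts for the size of this step.

This one step changes the group's size and brings in an aromatic ring together, so the compounds shown do not separate the contribution of the larger group from that of the ring itself. Cyclohexylmethyl, phenyl, methyl or a longer chain such as n-butyl on the same nitrogen would each address a different part of that question, and how any of them would read out remains open.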